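High Oral Exposure in Dogs Across a Shared Core

The compounds below may be only part of what the source reports. "The series", "measured", "known", "first", "only" and "open" are said of these compounds alone.

Compound 1, `CC(C)c1ncc([C@@H](CCCCCCc2ccc3c(n2)NCCC3)CC(=O)O)cn1` — an in vivo ADME assay on the whole organism (Canis lupus familiaris) for pharmacokinetics; on this read-out lower numbers stand for lower oral bioavailability and higher numbers for higher oral bioavailability: "not determined" (no result reported)
Compound 2, `O=C(O)C[C@H](CCCCCCc1ccc2c(n1)NCCC2)c1ccc2c(c1)OCC2` — this assay: > 99%

Only compound 2 carries a usable result, and that result is a limit of the assay rather than a number, (the limit of > 99% in this assay, at which 1 of the 2 values shown sits). Compound 3 is `COc1ccc([C@@H](CCCCCCc2ccc3c(n2)NCCC3)CC(=O)O)cn1`. Compared with compound 2, it carries a group of 8 heavy atoms (6 carbon, 1 nitrogen, 1 oxygen; one six-membered aromatic ring with 1 hetero atom) in place of a group of 9 heavy atoms (8 carbon, 1 oxygen; one five-membered non-aromatic ring with 1 hetero atom, one six-membered aromatic ring of carbon only), on a saturated chain carbon bound to two saturated chain carbons. For the measured compounds named here, no measured pair shows what such a swap does in this assay, so the size of the step from compound 2 to compound 3 cannot be read from the data; a modest fall that stays close to the scatter is expected, a number at least 14 percentage points lower from compound 2 to compound 3 (beyond the scatter). Compound 3 is therefore expected to give 85%, with a range from 55% to 99%.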

Compound 3, oral bioavailability: 49%
Compound 3: middle estimate off by 36 percentage points, on the high side; the whole stated range lies above it.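

With the shared core unchanged, putting 6-methoxypyridin-3-yl in place of the group of compound 2, on a saturated chain carbon bound to two saturated chain carbons, gives in this assay a number at least 50 percentage points lower from compound 2 to compound 3 (beyond the scatter). High oral bioavailability in dogs therefore does not come from the shared core alone, as the group at this one place can change it strongly. Compound 2 stands at a limit, not at a number: the limit of > 99% in this assay, at which 1 of the 3 values shown sits.

The compounds shown do not separate the effect of the ring nitrogen from that of the methoxy group. From the compounds shown here alone, how an unsubstituted phenyl ring or an amine at this place would behave remains open, and steps involving compound 1 cannot be read.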